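Mirror image of the weaker epimer at the free fatty acid receptor

The source may report more compounds than this note shows. Statements on the series, on what has been measured and on what is new or still open speak of the compounds shown alone.

Compound 2 `COc1ccc(F)c(-c2ccc(Cc3ccc(N4C[C@H](C(F)(F)F)C[C@H]4CC(=O)O)cc3)c(C)c2)c1` shows the highest number of the two measured in a functional assay on cells for agonist activity at Free fatty acid receptor 1 (Mus musculus), read by FLIPR and calcium flux, with a stated time of 100 s (a lower number here means that less compound is needed, a higher number that more compound is needed for the effect), where compound 2 gives 1100 nM and compound 1 `COc1ccc(F)c(-c2ccc(Cc3ccc(N4C[C@H](C(F)(F)F)C[C@@H]4CC(=O)O)cc3)c(C)c2)c1` gives 54 nM. Compound 3 `COc1ccc(F)c(-c2ccc(Cc3ccc(N4C[C@@H](C(F)(F)F)C[C@@H]4CC(=O)O)cc3)c(C)c2)c1` differs from compound 2 in this way: the two compounds have the same atoms and bonds and differ only in configuration as drawn: 2 of 2 stereo elements differ (all stereocentres are inverted: mirror images); a stereocentre at a saturated ring carbon is drawn R in compound 2 and S in compound 3; a stereocentre at a saturated ring carbon is drawn S in compound 2 and R in compound 3. Among the measured compounds shown here, the only measured step, a 20-fold higher number from compound 1 to compound 2 (1.31 log units; beyond the scatter), is large, and that pair differs only in configuration (the fact that compounds 1 and 2 differ only in the configuration as drawn). Since compound 3 is the mirror image of compound 2, a change beyond the scatter is expected, most likely downward, although the size is uncertain. Compound 3 is therefore estimated at 250 nM, within 50 nM to 1500 nM, a step of a 4.4-fold lower number from compound 2 to compound 3 (0.64 log units; beyond the scatter).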

Compound 3, half-maximal effective concentration: 53 nM
Compound 3: the middle estimate sits 4.7-fold (0.67 log units) above what was measured, and the stated range covers the measured number.
By their numbers in this assay, from the lowest: compounds 3 and 1 (each within the scatter of the next); then compound 2.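

The step back, a 21-fold lower number from compound 2 to compound 3 (1.32 log units; beyond the scatter), matches in size the earlier effect of inverting a single stereocentre, although here both stereocentres are inverted. Compound 3 keeps the stereocentre that separates compound 1 from compound 2 as it is in compound 1 and inverts only the other, and a 1.0-fold lower number from compound 1 to compound 3 (0.01 log units; within the scatter) shows that in this assay this second inversion has no effect beyond the scatter. Among these compounds, therefore, only the first stereocentre is seen to matter.

Going by these compounds, it remains open how the mirror image of compound 1 would read, and so whether the second stereocentre is also silent in the configuration of compound 2. On these data alone, it is also open whether this pattern would hold with a nitrile in place of the trifluoromethyl group.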